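A few compounds are considered here, and "the series" means these few. Any claim that something is new, unique, unknown or untested is made for them only; others in the source may bear on it.

Measured so far in a physicochemical assay for solubility, read by spectrophotometry, in phosphate buffer, with a stated time of 18 h, at pH 7.4 (on this read-out higher numbers stand for higher solubility and lower numbers for lower solubility), are these compounds:

compound 1 `CCc1ccc(-c2nc3c(c(C)nn3-c3ccccc3)c(-c3ccccc3O)c2C#N)cc1` gives 3100 nM
compound 2 `CCc1ccc(-c2nc3c(c(C)nn3-c3ccccc3)c(-c3ccccc3Cl)c2C#N)cc1` gives 1700 nM
compound 3 `Cc1cccc(-c2nc3c(c(C)nn3-c3ccccc3)c(-c3ccccc3O)c2C#N)c1` gives 42000 nM

Compound 3 stands highest of these three at 42000 nM and its gaps to the other two lie beyond the usual scatter. The next compound is compound 4 `Cc1nn(-c2ccccc2)c2nc(-c3ccc(C(C)C)cc3)c(C#N)c(-c3ccccc3O)c12` which keeps the shared core and changes one group. It carries 4-isopropylphenyl in place of 3-methylphenyl on an aromatic carbon next to the ring nitrogen and ortho to a cyano group 4-isopropylphenyl in place of 3-methylphenyl on an aromatic carbon and its 2-hydroxyphenyl group stays.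

The measured step that bears most on this is a 14-fold higher number from compound 1 to compound 3 (1.13 log units; beyond the scatter) and it was large. It exchanges the group at this same place, with 3-methylphenyl in place of 4-ethylphenyl. The 4-isopropylphenyl of compound 4 looks far more like the 4-ethylphenyl of compound 1 than the group it replaces, so a similarly large drop in this assay is expected. This rests on a single pair of compounds. The other step, a 1.8-fold lower number from compound 1 to compound 2 (0.26 log units; within the scatter), concerns a different place and says little here.

The expected step is a 17-fold lower number from compound 3 to compound 4 (1.23 log units; beyond the scatter) and it would bring the number back near that of compound 1 at 3100 nM in this read-out. The estimate for compound 4 is 2500 nM with an expected range from 700 nM to 9000 nM.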

Compound 4, solubility: 9800 nM
For compound 4 the middle estimate is 3.9-fold (0.59 log units) below the measured one; the measured number lies above the stated range.
By their numbers in this assay, from the lowest: compounds 2 and 1 (each within the scatter of the next); then compound 4; then compound 3.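

In this assay the change at this position gives a 4.3-fold lower number from compound 3 to compound 4 (0.63 log units; beyond the scatter) and this step is modest. Compound 4 carries a 4-alkylphenyl group as compound 1 does, yet the numbers of these two compounds do not match. The two closely related groups also differ from each other: one extra methyl on the chain, turning 4-ethylphenyl into 4-isopropylphenyl, gives a 3.2-fold higher number from compound 1 to compound 4 (0.50 log units; beyond the scatter) and this shows that even a small branch on this group goes with a step beyond the scatter, and upward rather than downward. The order among these three compounds with the 2-hydroxyphenyl group therefore does not follow the number of carbons in the group, and nothing available here accounts for that order.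

As far as these compounds go, the groups at this position are all phenyl rings with carbon-only chains, so it remains open how the number would respond to an amine or a carboxylic acid on that ring. From the compounds shown here alone, it is also open whether compound 3 stands highest through the 3-position of its methyl or through the small size of that group, a question that 4-methylphenyl or 3-ethylphenyl at the same place could help to separate.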